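Swapping the Para Group: From Compound 3 to Compound 4

The source may report more compounds than this note shows. Statements on the series, on what has been measured and on what is new or still open speak of the compounds shown alone.

Of the compounds shown here, three built on one shared core have been tested in an assay for inhibition of 15-hydroxyprostaglandin dehydrogenase [NAD(+)] (Homo sapiens), read by fluorescence, with a stated time of 15 min, in the presence of a further agent that is not named here; a lower number here means a stronger inhibitor, a higher number a weaker inhibitor. Compound 1 `CCCC[S+]([O-])c1sc2nc(-c3nccs3)cc(-c3ccc(COC(=O)NCC)cc3)c2c1N` gives 3.4 nM. Compound 2 `CCCC[S+]([O-])c1sc2nc(-c3nccs3)cc(-c3ccc(CNC(=O)NCC)cc3)c2c1N` gives 2.1 nM, and compound 3 `CCCC[S+]([O-])c1sc2nc(-c3nccs3)cc(-c3ccc(CNS(C)(=O)=O)cc3)c2c1N` gives 4.6 nM. Among the measured compounds shown here, compound 3 thus shows the highest number of the three, but the step of a 1.4-fold higher number from compound 1 to compound 3 (0.13 log units; within the scatter) lies within the scatter, while only the step of a 2.2-fold higher number from compound 2 to compound 3 (0.34 log units; beyond the scatter) lies beyond it, so compound 2 is the one compound clearly set apart from compound 3 in this assay.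

Compound 4 `CCCC[S+]([O-])c1sc2nc(-c3nccs3)cc(-c3ccc(C(=O)OC)cc3)c2c1N` has not yet been measured. It differs from compound 3 in a single place: methoxycarbonyl in place of (methanesulfonamido)methyl on an aromatic carbon, on a six-membered aromatic ring of carbon only, para to a large group.

All three measured steps alter this same group. The step of a 1.6-fold lower number from compound 1 to compound 2 (0.21 log units; within the scatter) and the step of a 1.4-fold higher number from compound 1 to compound 3 (0.13 log units; within the scatter) stayed within the scatter, and the step of a 2.2-fold higher number from compound 2 to compound 3 (0.34 log units; beyond the scatter) was only modest. Exchanging this group has so far moved the numbers little in this assay. For compound 4 the expected step is small, with no firm direction, estimated as a 1.1-fold higher number from compound 3 to compound 4 (0.04 log units; within the scatter). Compound 4 is therefore expected to give about 5 nM in this assay, within a range from 2 nM to 13 nM.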

Compound 4, half-maximal inhibitory concentration: 15.1 nM
Compound 4: middle estimate off by 3.0-fold (0.48 log units), on the low side; measured number outside the range, above it.
By their numbers in this assay, from the lowest: compounds 2, 1 and 3 (each within the scatter of the next, the first and the last beyond it); then compound 4.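

In this assay, this position turns out not to accept every exchange: compound 4 is the weakest of the four, with a 3.3-fold higher number from compound 3 to compound 4 (0.52 log units; beyond the scatter) and, against the other two, a 4.4-fold higher number from compound 1 to compound 4 (0.65 log units; beyond the scatter) and a 7.2-fold higher number from compound 2 to compound 4 (0.86 log units; beyond the scatter) as well. Among the compounds shown here, all three steps are larger than any step among the earlier compounds, which all kept a saturated chain carbon bound to the aromatic carbon and varied only what hung from that carbon, whereas methoxycarbonyl sits directly on the aromatic carbon. The small steps seen before therefore describe that one family of groups, not the position as a whole, and nothing available here explains why the number rose.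

The change from compound 3 to compound 4 removes the saturated chain carbon, the nitrogen and the hydrogen-bond donor in one move, so the compounds shown cannot separate these features from one another. Going by these compounds, it remains open whether a methoxycarbonyl held on a saturated chain carbon, or a carboxylic acid or primary amide placed directly on the aromatic carbon, would stay close to compound 3 or fall nearer compound 4.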